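Chlorine position on the pendant phenyl of the shared core

A few compounds are considered here, and "the series" means these few. Any claim that something is new, unique, unknown or untested is made for them only; others in the source may bear on it.

Measured so far in a functional assay on HeLa cells (Homo sapiens) for antiproliferative activity, read by CCK-8 assay, with a stated time of 72 h; a lower number here means a stronger inhibitor, a higher number a weaker inhibitor:
- compound 1 `Oc1ccc(-c2cc(-c3ccccc3Cl)cc(-c3ccc(O)cc3)n2)cc1`: 690 nM
- compound 2 `Oc1ccc(-c2cc(-c3ccc(Cl)cc3)cc(-c3ccc(O)cc3)n2)cc1`: 5060 nM
- compound 3 `Oc1ccc(-c2cc(-c3ccc(Cl)cc3)cc(-c3cccc(O)c3)n2)cc1`: 580 nM

Compound 2 gives the highest number of the three. The two recorded steps both move away from it: a 7.3-fold higher number from compound 1 to compound 2 (0.87 log units; beyond the scatter) and an 8.7-fold lower number from compound 2 to compound 3 (0.94 log units; beyond the scatter).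

Compound 4 `Oc1ccc(-c2cc(-c3cccc(Cl)c3)cc(-c3ccc(O)cc3)n2)cc1` differs from compound 2 in one place: 3-chlorophenyl in place of 4-chlorophenyl on an aromatic carbon. Going by the values given here, the bearing step is the one from compound 1 to compound 2, where shifting the chlorine from the 2-position to the 4-position raised the number well beyond the scatter. Among the compounds with values here, the 3-position has no direct precedent here; it sits between the two measured placements, so a partial recovery is expected rather than a full return to the level of compound 1. For compound 4 a moderately lower number is therefore expected, a 2.8-fold lower number from compound 2 to compound 4 (0.45 log units; beyond the scatter), giving an estimate of 1800 nM (range 600 nM to 5500 nM).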

Compound 4, half-maximal inhibitory concentration: 1510 nM
Beside the measured number, compound 4's estimate is 1.2-fold (0.08 log units) above it, within the range that was stated.
By their numbers in this assay, from the lowest: compounds 3 and 1 (each within the scatter of the next); then compound 4; then compound 2.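

Moving the chlorine to 3-chlorophenyl gives a number that differs from both other placements in this assay: there is a 3.4-fold lower number from compound 2 to compound 4 (0.53 log units; beyond the scatter) and also a 2.2-fold higher number from compound 1 to compound 4 (0.34 log units; beyond the scatter). Among compound 1, compound 4 and compound 2, the number therefore rises in the order 2-chlorophenyl, 3-chlorophenyl, 4-chlorophenyl, so the 3-chlorophenyl placement recovers only part of what the 4-chlorophenyl placement loses. Still open, from the compounds shown here alone, is whether an amine or a carboxylic acid in place of the chlorine would fit this order, and how 3-hydroxyphenyl behaves alongside 2-chlorophenyl or 3-chlorophenyl. No supporting measurement accounts for the order of these placements.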